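Swapping carboxy for methoxy: an expected cytotoxicity step

The source may hold more compounds than are shown below. What is called first, only, known or untested is meant among the compounds shown, and "the series" means these compounds.

Two compounds so far have values in an ADME assay on HEK293 cells (Homo sapiens) for cytotoxicity, with a stated time of 72 h (on this read-out higher numbers stand for an effect only at larger amounts of compound and lower numbers for an effect already at smaller amounts), as follows:
Compound 1 `COC(=O)c1ccc(NC(=O)Nc2cc(C)nc3ccccc23)cc1` gives 15000 nM as a number
Compound 2 `Cc1cc(NC(=O)Nc2ccc(C(=O)O)cc2)c2ccccc2n1` gives > 25000 nM as a limit of the assay

Compound 2 stands at > 25000 nM as a limit and not a number. Its standing is the limit of > 25000 nM in this assay, at which 1 of the 2 values shown sits, and nothing finer can be said. Compound 3 `COc1ccc(NC(=O)Nc2cc(C)nc3ccccc23)cc1` carries methoxy in place of carboxy on an aromatic carbon, para to a large group (methoxy in place of carboxy on an aromatic carbon). Among the measured compounds shown here, the one measured step bearing on this is an at least 1.6-fold higher number from compound 1 to compound 2 (0.22 log units; that floor lies within the scatter) and its floor lies within the scatter. Going by compound 1 at 15000 nM in this assay and by that step, a modest move toward a lower number is expected for compound 3. The estimated step is an at least 1.7-fold lower number from compound 2 to compound 3 (0.25 log units; that floor lies within the scatter) and it may prove no larger than the scatter. The expected value for compound 3 is 14000 nM with an estimated range of 5000 nM to 25000 nM in this assay once measured.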

Compound 3, half-maximal effective concentration: > 25000 nM
Compound 3 was reported as a limit (the forecaster's own chance of this, stated with the estimate: 30%); middle value at least 1.7-fold (0.25 log units) from the limit.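

In this assay compound 3 gives > 25000 nM, which is a limit of the assay and not a number. Methoxy in place of methoxycarbonyl on an aromatic carbon, para to a large group, gives an at least 1.6-fold higher number from compound 1 to compound 3 (0.22 log units; that floor lies within the scatter), so this change shows no clear shift at this position. The step between compound 2 and compound 3 cannot be read, but this position now holds carboxy, with a hydrogen-bond donor, and methoxy, with none, at the same limit: the limit of > 25000 nM in this assay, at which 2 of the 3 values shown sit.

Going by these compounds, how far compound 2 and compound 3 lie from that limit stays open, and so does whether compound 1 truly differs from them. An amine or a longer chain on the same aromatic carbon could show whether any group at this position gives a clear number.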